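Chloro to hydrogen on compound 2: expected step

The source may report more compounds than this note shows. Statements on the series, on what has been measured and on what is new or still open speak of the compounds shown alone.

Compound 1 `CCN(CC)CN1C(=O)/C(=N/NC(=S)Nc2ccccc2)c2cc(Cl)ccc21`, compound 2 `CCN(CC)CN1C(=O)/C(=N/NC(N)=S)c2cc(Cl)ccc21` and compound 3 `CCN(CC)CN1C(=O)/C(=N/NC(=S)Nc2ccc(Cl)cc2)c2cc(Cl)ccc21` share a core and differ on the amide-type nitrogen. In a functional assay on CCRF-CEM cells (Homo sapiens) for inhibition, read by cell counting, with a stated time of 72 h (on this read-out lower numbers stand for stronger inhibition and higher numbers for weaker inhibition), compound 1 gives 40000 nM and compound 2 gives 71000 nM. These two are separated by a 1.8-fold higher number from compound 1 to compound 2 (0.25 log units; within the scatter), so compound 2 stands level with compound 1. Compound 3 reaches only a limit, > 125000 nM.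

Compound 4 `CCN(CC)CN1C(=O)/C(=N/NC(N)=S)c2ccccc21` carries one change from compound 2: hydrogen in place of chloro on an aromatic carbon. Going by the values given here, no measured step makes this change on the shared core. The closest in kind is an at least 3.1-fold higher number from compound 1 to compound 3 (0.49 log units; beyond the scatter), chloro in place of hydrogen on an aromatic carbon, but that chloro sits on the phenyl group and the step is bounded by a limit. The step of an at least 1.7-fold higher number from compound 2 to compound 3 (0.24 log units; that floor lies within the scatter) also changes the amide-type nitrogen, so it bears less directly. Read in reverse, the step from compound 1 gives only a weak hint towards a lower number when a chloro leaves, and a shift within the scatter is expected. The expected step is a 1.3-fold lower number from compound 2 to compound 4 (0.11 log units; within the scatter). Compound 4 is estimated at 55000 nM, with an expected range from 22000 nM to 125000 nM.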

Compound 4, half-maximal inhibitory concentration: 164000 nM
Beside the measured number, compound 4's estimate is 3.0-fold (0.47 log units) below it, outside the stated range (above it).
By their numbers in this assay, from the lowest: compounds 1 and 2 (each within the scatter of the next); then compound 4.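

In this assay, going by these compounds alone, hydrogen in place of chloro on the aromatic carbon of the fused system gives a 2.3-fold higher number from compound 2 to compound 4 (0.36 log units; beyond the scatter), so on this core the chloro goes with the lower number, which no earlier pair could show at this position. The direction is opposite to that of the chloro added to the phenyl group, so what a chloro does at one place cannot be carried over to the other in this series: the same change on two cores in this assay, an at least 3.1-fold higher number (0.49 log units; beyond the scatter) from compound 1 to compound 3 and a 2.3-fold lower number (0.36 log units; beyond the scatter) from compound 4 to compound 2, at least 7.2-fold (0.85 log units) apart, beyond the scatter of two such steps Compound 3 is a limit, > 125000 nM, so the phenyl side of that comparison has a floor and no measured size: the limit of > 125000 nM in this assay, at which 1 of the 4 values shown sits.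

As far as these compounds go, only chloro and hydrogen are compared at this position, and only on the core with the unsubstituted thiosemicarbazone nitrogen, so it remains open whether the same step holds on the core of compound 1, where the nitrogen carries phenyl. From the compounds shown here alone, it also remains open whether a bromo, a methoxy or an amine at this position would read with the chloro of compound 2 or with the hydrogen of compound 4.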